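A larger group on the amide-type nitrogen

The compounds below may be only part of what the source reports. "The series", "measured", "known", "first", "only" and "open" are said of these compounds alone.

Compound 1 `CCn1c(C(=O)N[C@@H](CC(=O)OC)C(=O)OC)ccc1C(CC)(CC)c1ccc(OCS(=O)(=O)c2ccccc2)c(C)c1`: > 50000 nM, a limit of the assay
Compound 2 `CCn1c(C(=O)NCCCO)ccc1C(CC)(CC)c1ccc(OCS(=O)(=O)c2ccccc2)c(C)c1`: 42000 nM

Among the measured compounds shown here, in a functional assay on MCF7 cells (Homo sapiens) for antiproliferative activity, read by MTT assay, with a stated time of 24 h (on this read-out lower numbers stand for stronger inhibition and higher numbers for weaker inhibition), compound 2 gives 42000 nM, the only actual number so far. Compound 1 reports only a limit, as the limit of > 50000 nM in this assay, at which 1 of the 2 values shown sits, records.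

Compound 3 `CCn1c(C(=O)N[C@H](CO)CCCO)ccc1C(CC)(CC)c1ccc(OCS(=O)(=O)c2ccccc2)c(C)c1` keeps the shared core of compound 2 and changes one group: a group of 7 heavy atoms (5 carbon, 2 oxygen; no ring) in place of a group of 4 heavy atoms (3 carbon, 1 oxygen; no ring), on an amide-type nitrogen. The entering group also carries one defined stereocentre, and neither group has a net charge.

For the measured compounds named here, one measured step bears on this change, a swap on the same amide-type nitrogen: an at least 1.1-fold lower number from compound 1 to compound 2 (0.07 log units; that floor lies within the scatter). Going by the values given here, with only that small step as a guide, no change beyond the scatter is expected in this assay, in either direction. The expected step is a 1.1-fold lower number from compound 2 to compound 3 (0.02 log units; within the scatter), which is an estimate. For compound 3 the estimated value is 40000 nM, with an expected range from 18000 nM to 50000 nM. Compound 3 may also turn out to give only a limit and no number.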

Compound 3, half-maximal inhibitory concentration: 31400 nM
Estimate against measurement, compound 3: 1.3-fold (0.11 log units) above; the measured number falls inside the stated range.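

The larger group, with its 7 heavy atoms, 2 hydrogen-bond donors and one defined stereocentre, can take the place of 3-hydroxypropyl on this amide-type nitrogen without a clear shift in this assay: the result is a 1.3-fold lower number from compound 2 to compound 3 (0.13 log units; within the scatter). Set against the 1,2-bis(methoxycarbonyl)ethyl group on the same nitrogen, the new group gives an at least 1.5-fold lower number from compound 1 to compound 3 (0.20 log units; that floor lies within the scatter). Compound 1 gives a limit and not a number, so that step is only a floor and its true size stays unknown: the limit of > 50000 nM in this assay, at which 1 of the 3 values shown sits.

No step shown so far lies beyond the scatter, so it remains open whether an amine, a carboxylic acid or a longer carbon chain on this nitrogen would move the number by a clear margin. From the compounds shown here alone, it is equally open whether the defined stereocentre in compound 3 matters at all, a question that the opposite arrangement at that centre could answer.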